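From urea to amide on a shared core

The source may report more compounds than this note shows. Statements on the series, on what has been measured and on what is new or still open speak of the compounds shown alone.

Compound 1 `COc1cc(-c2nn(-c3cccc(NC(=O)Nc4ccc(Cl)c(Cl)c4)c3)cc2-c2ccncc2)ccc1Cl` reached only the limit of > 50000 nM in a functional assay on Hs-578T cells (Homo sapiens) for inhibition, read by sulforhodamine B assay, with a stated time of 48 h; a lower number here means a stronger inhibitor of growth, a higher number a weaker inhibitor of growth. Within the data shown here, compound 2 `COc1cc(-c2nn(-c3cccc(NC(=O)Nc4cccc(C(F)(F)F)c4)c3)cc2-c2ccncc2)ccc1Cl` gave 12500 nM in this assay, the only number among the two values shown, and the step of an at least 4.0-fold lower number from compound 1 to compound 2 (0.60 log units; beyond the scatter) sits against (the limit of > 50000 nM in this assay, at which 1 of the 2 values shown sits). Compound 3 `COc1cc(-c2nn(-c3cccc(NC(=O)c4ccc(Cl)c(C(F)(F)F)c4)c3)cc2-c2ccncc2)ccc1Cl` carries 4-chloro-3-(trifluoromethyl)phenyl in place of (3-(trifluoromethyl)phenyl)amino on a carbonyl carbon. Among the measured compounds shown here, no measured step covers this change directly; only the step from compound 1 to compound 2 touches the aryl substitution, and it did so with an unmeasured lower end. The estimated step of a 1.2-fold higher number from compound 2 to compound 3 (0.08 log units; within the scatter) is therefore expected to be small, without a firm direction. Compound 3 is estimated at 15000 nM in this assay, expected between 4000 nM and 60000 nM.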

Compound 3, concentration for total growth inhibition: > 32500 nM
Compound 3: no number, only a limit; the forecaster's own chance of this, stated with the estimate: 30%; middle value at least 2.1-fold (0.33 log units) from the limit.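

At the carbonyl carbon, 4-chloro-3-(trifluoromethyl)phenyl in place of (3-(trifluoromethyl)phenyl)amino gives an at least 2.6-fold higher number from compound 2 to compound 3 (0.41 log units; beyond the scatter) in this assay, so this urea-to-amide change, unlike the earlier aryl swap, weakens growth inhibition relative to compound 2. On these data alone, compound 3 gives only a limit, so the full size of this step is unknown: the limit of > 32500 nM in this assay, at which 1 of the 3 values shown sits. The step from compound 1 to compound 3 cannot be read, as both values are limits. As far as these compounds go, whether the loss follows the departing nitrogen or the added chlorine stays open, as does the effect of an amine or a carboxylic acid on that phenyl ring.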